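The source may report more compounds than this note shows. Statements on the series, on what has been measured and on what is new or still open speak of the compounds shown alone.

Compound 1 `FC(F)(F)c1ccc(NCc2cn(-c3ccccc3)nc2-c2ccc(Br)cc2)cc1` is measured in an ADME assay on BHK-21 cells (Mesocricetus auratus) for cytotoxicity, read by MTT assay, with a stated time of 72 h (on this read-out higher numbers stand for lower toxicity in this test and lower numbers for higher toxicity in this test), where compound 1 gives 20000 nM. Compound 3 `FC(F)(F)c1ccc(NCc2cn(-c3ccccc3)nc2-c2ccccc2)cc1` differs from compound 1 only in hydrogen in place of bromo on an aromatic carbon, and in this assay compound 3 gives 37000 nM; the change brings a 1.9-fold higher number from compound 1 to compound 3 (0.27 log units; within the scatter). Compound 2 `Cc1ccc(-c2nn(-c3ccccc3)cc2CNc2ccc(Br)cc2)cc1` carries a different core, and how it differs from compound 1 is not broken down here. In this assay compound 2 reaches only a limit of the assay, reported as > 100000 nM, which is the limit of > 100000 nM in this assay, at which 1 of the 3 values shown sits.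

Compound 4 `Cc1ccc(-c2nn(-c3ccccc3)cc2CNc2ccccc2)cc1` is not yet measured. It stands to compound 2 as compound 3 stands to compound 1, namely by hydrogen in place of bromo on an aromatic carbon, the same change at the same place. With compound 1 and compound 3 showing a 1.9-fold higher number from compound 1 to compound 3 (0.27 log units; within the scatter), a step within the scatter, the step from compound 2 to compound 4 in this assay is expected to be similarly small, estimated at a step that the limit leaves unreadable from compound 2 to compound 4. Given that compound 2 sits at > 100000 nM, compound 4 is expected to give about 150000 nM in this assay, with a likely range from 60000 nM to 400000 nM, and most probably again only a limit.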

Compound 4, half-maximal cytotoxic concentration: > 100000 nM
Compound 4 was reported as a limit; the forecaster's own chance of this, stated with the estimate: 70%; the middle value lies beyond the limit too.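

In this assay compound 4 gives > 100000 nM, which is a limit of the assay and not a number. Compound 2 is also reported only as a limit, so no step from compound 2 to compound 4 can be read: the limit of > 100000 nM in this assay, at which 2 of the 4 values shown sit.

The compounds shown leave open how far past this limit compound 2 and compound 4 lie.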